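A few compounds are considered here, and "the series" means these few. Any claim that something is new, unique, unknown or untested is made for them only; others in the source may bear on it.

Compound 1 `COc1cc(-c2nnc3n2NC(c2ccco2)C(C(=O)c2ccco2)S3)cc(OC)c1OC` was tested in a functional assay on PC-3 cells (Homo sapiens) for cytotoxicity, read by MTT assay, with a stated time of 48 h (on this read-out lower numbers stand for stronger inhibition and higher numbers for weaker inhibition), and gives 58300 nM. Among the three compounds measured so far, compound 1 sits second highest, with both other numbers within the scatter of repeated measurements. Compound 2 `COc1cc(-c2nnc3n2NC(c2ccco2)C(C(=O)c2ccc(C(F)(F)F)cc2)S3)cc(OC)c1OC` gives 77500 nM in this assay, and compound 3 `COc1cc(-c2nnc3n2NC(c2ccco2)C(C(=O)c2ccc(-c4ccccc4)cc2)S3)cc(OC)c1OC` gives 45900 nM. The steps between these three are all small: a 1.3-fold higher number from compound 1 to compound 2 (0.12 log units; within the scatter), a 1.3-fold lower number from compound 1 to compound 3 (0.10 log units; within the scatter), and a 1.7-fold lower number from compound 2 to compound 3 (0.23 log units; within the scatter).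

Compound 4 `COc1cc(-c2nnc3n2NC(c2ccco2)C(C(=O)c2ccc(Cl)cc2)S3)cc(OC)c1OC` has not yet been measured. It differs from compound 1 in one place: 4-chlorophenyl in place of furan-2-yl on a carbonyl carbon. The two measured steps that bear on this change each swap the same furan-2-yl on a carbonyl carbon for a different six-membered aromatic ring, and neither moved the number beyond the scatter. On that basis no step beyond the scatter is expected for compound 4, and the expected step from compound 1 is a 1.0-fold higher number from compound 1 to compound 4 (0.01 log units; within the scatter). Compound 4 is therefore estimated at 60000 nM, with an expected range from 30000 nM to 120000 nM.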

Compound 4, half-maximal inhibitory concentration: 67800 nM
The estimate for compound 4 lay 1.1-fold (0.05 log units) below the measured number, and the stated range covers the measured number.
By their numbers in this assay, from the lowest: compounds 3, 1, 4 and 2 (each within the scatter of the next).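

In this assay the 4-chlorophenyl group gives a 1.2-fold higher number from compound 1 to compound 4 (0.07 log units; within the scatter) and so, like the two earlier swaps on this carbonyl carbon, stays within the scatter, now with a chlorine-bearing ring in this place. The new compound also allows the group on the six-membered ring to be compared directly: chloro in place of phenyl gives a 1.5-fold higher number from compound 3 to compound 4 (0.17 log units; within the scatter) and chloro in place of trifluoromethyl gives a 1.1-fold lower number from compound 2 to compound 4 (0.06 log units; within the scatter) and neither step goes beyond the scatter. No measurement is available to explain why these steps are so small.

From the compounds shown here alone, it remains open whether an amine, a carboxylic acid or a plain alkyl chain in place of the aromatic ring on this carbonyl carbon would move the number beyond the scatter. Also open, going by these compounds, is whether changes to the shared core would matter more than changes at this position.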